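A few compounds are considered here, and "the series" means these few. Any claim that something is new, unique, unknown or untested is made for them only; others in the source may bear on it.

Of the compounds shown here, three sharing one core have been measured in a functional assay on the whole organism for positive allosteric modulation, with Mus musculus as the target; a higher number here means that more compound is needed for the effect, a lower number that less compound is needed. Among them, compound 2 (`CCC(=O)N(c1cccc(OC)c1)C1CCCC1N(C)C`) has the lowest number, at 0.8 mg/kg. Compound 1 (`CCCC(=O)N(c1ccc(Cl)c(Cl)c1)C1CCCC1N(C)C`) gives 2 mg/kg, and compound 3 (`CCC(=O)N(c1ccc(OC)c(OC)c1)C1CCCC1N(C)C`) stands furthest up at 9 mg/kg. The compound still to be measured, compound 4 (`CCC(=O)N(c1cccc(Br)c1)C1CCCC1N(C)C`), differs from compound 2 by one change: bromo in place of methoxy on an aromatic carbon, in words bromo in place of methoxy on an aromatic carbon.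

Among the compounds with values here, only one measured step involves a single change on that ring: an 11-fold higher number from compound 2 to compound 3 (1.05 log units; beyond the scatter), a large step, for methoxy in place of hydrogen on an aromatic carbon. Within the data shown here, it shows that this assay can respond strongly to one ring substituent, but it is not the same exchange, and no measured pair swaps methoxy for bromo. Compound 1 offers a loose guide to a halogen-bearing ring at 2 mg/kg, though its chloro groups come with a different acyl chain. A modest move toward a higher number is therefore expected, well short of the large step to compound 3. The expected change is a 2.3-fold higher number from compound 2 to compound 4 (0.35 log units; beyond the scatter). For compound 4 the estimated value is 1.8 mg/kg, with an expected range of 0.6 mg/kg to 5 mg/kg.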

Compound 4, dose for half-maximal effect: 0.1 mg/kg
The estimate for compound 4 lay 18-fold (1.26 log units) above the measured number; measured number outside the range, below it.
By their numbers in this assay, from the lowest: compound 4; then compound 2; then compound 1; then compound 3.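

In this assay the exchange of methoxy for bromo on an aromatic carbon, meta to a large group, gives an 8.0-fold lower number from compound 2 to compound 4 (0.90 log units; beyond the scatter) and so shows that a single substituent at this place can lower the number. Within the data shown here, the one earlier single change on this ring, methoxy in place of hydrogen, had given an 11-fold higher number from compound 2 to compound 3 (1.05 log units; beyond the scatter) and showed only a rise, so the two steps together show that the number can move in either direction from compound 2. The new exchange replaces two heavy atoms, one carbon and one oxygen, including one hydrogen-bond acceptor, with a single bromine that has none, yet the compounds alone cannot say which of these differences matters, and no measurement of any property of the two groups is available to bear on the result.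

The compounds shown leave open whether chloro, iodo or a nitrile at the same place would give a number like that of compound 4 or that of compound 2. They also leave open whether bromo would have the same effect alongside a second ring substituent or with a butanoyl chain in place of the propanoyl chain.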